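A few compounds are considered here, and "the series" means these few. Any claim that something is new, unique, unknown or untested is made for them only; others in the source may bear on it.

Of the compounds shown here, three built on a shared core have been measured in an assay on CHO cells for displacement of a labelled ligand from adenosine receptor A1 (Homo sapiens), read by scintillation counting, tested at 10 uM; a higher number here means more inhibition at the concentration tested (going by the name of the read-out), a lower number less inhibition. Compound 1 `Cc1csc(N)c1C(=O)c1ccc(Cl)cc1` gives 1% in this assay. Compound 2 `COc1ccc(-c2sc(N)c(C(=O)c3ccc(Cl)cc3)c2C)cc1` gives 1% in this assay, and the step of no change at the digits printed from compound 1 to compound 2 (within the scatter), 4-methoxyphenyl in place of hydrogen on an aromatic carbon, stays within the scatter. Compound 3 `CC(C)(C)Cc1c(-c2cc(F)ccc2F)sc(N)c1C(=O)c1ccc(Cl)cc1` gives 3% in this assay; this is the highest of the three numbers, yet the values of compound 1 and compound 2 both lie within the scatter of it, so the three numbers are level on these data.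

Compound 4 `CC(C)c1ccc(-c2sc(N)c(C(=O)c3ccc(Cl)cc3)c2CC(C)(C)C)cc1` is still to be measured in this assay. It differs from compound 3 by 4-isopropylphenyl in place of 2,5-difluorophenyl on an aromatic carbon. Among the measured compounds shown here, the only measured step that bears on this place is the one from compound 1 to compound 2, which put an aryl group onto the same aromatic carbon and gave no change beyond the scatter. Compound 2 and compound 3, carrying different aryl groups there, also give values within the scatter of each other. The expected step of no change at the digits printed from compound 3 to compound 4 (within the scatter) is therefore none beyond the scatter. The estimate for compound 4 in this assay is 3%, with a range from -5% to 12%.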

Compound 4, a percentage reported as inhibition, at one concentration (the size of the read-out at that concentration, not a potency): 1%
Estimate against measurement, compound 4: 2 percentage points above; the measured number falls inside the stated range.
By their numbers in this assay, from the lowest: compounds 1, 2, 4 and 3 (each within the scatter of the next).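

In this assay, exchanging 2,5-difluorophenyl for 4-isopropylphenyl on the aromatic carbon next to the ring sulfur gives a number 2 percentage points lower from compound 3 to compound 4 (within the scatter), so this change leaves the read-out level. Among the compounds shown here, the earlier step showed only that placing 4-methoxyphenyl on this carbon instead of hydrogen left the number level, whereas this is the first single-place exchange of one aryl group for another there, made with the neopentyl group on the neighbouring ring atom; the fluorines leave and an isopropyl group enters without any change beyond the scatter. No measurement is available that explains this flat result.

All four compounds give numbers close together at the low end of the scale and carry the same (4-chlorophenyl)carbonyl and amino groups, so these data cannot show whether any group on this carbon can raise the inhibition at the concentration tested. Going by these compounds, it remains open whether a carboxylic acid or an aminomethyl group on the aryl ring, or a longer chain in place of the neopentyl group, would move the number beyond the scatter.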